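A few compounds are considered here, and "the series" means these few. Any claim that something is new, unique, unknown or untested is made for them only; others in the source may bear on it.

Measured compounds in a toxicity assay on HepG2 cells (Homo sapiens) for inhibition, read by CellTiter-Glo, with a stated time of 48 h; on this read-out higher numbers stand for weaker inhibition and lower numbers for stronger inhibition:
- Compound 1 `COc1ccc2nc(C)cc(OCC(=O)Nc3cc(C)cc(C)c3)c2c1` gives 20000 nM.
- Compound 2 `Cc1cc(C)cc(NC(=O)COc2cc(C)nc3ccc(OCc4ccccc4)cc23)c1` gives only a limit of the assay, > 100000 nM.

Among the measured compounds shown here, compound 1 stands alone as the one compound with an actual number in this assay; the other value shown is a limit. For the measured compounds named here, the single measured step, an at least 5.0-fold higher number from compound 1 to compound 2 (0.69 log units; beyond the scatter), is at least modest and beyond the scatter, and its size is known only as a lower bound (the limit of > 100000 nM in this assay, at which 1 of the 2 values shown sits).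

Compound 3 `COc1ccc2nc(C)cc(OCC(=O)Nc3cc(C)c(F)c(C)c3)c2c1` differs from compound 1 in one place: fluoro in place of hydrogen on an aromatic carbon. Going by the values given here, this change sits on the dimethylphenyl amide end of the molecule, whereas the one measured step concerns the other end of the shared core, where a benzyloxy replaces a methoxy. Among the compounds with values here, no measured step therefore bears on the change from compound 1 to compound 3, and nothing in the data points to a shift in either direction.

For compound 3 the expected step is no change at the digits printed from compound 1 to compound 3 (within the scatter), that is, none beyond the scatter. Compound 3 is accordingly estimated at 20000 nM, in the range 7000 nM to 60000 nM.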

Compound 3, half-maximal inhibitory concentration: > 100000 nM
Compound 3: only a limit was reported (the forecaster's own chance of this, stated with the estimate: 15%); middle value at least 5.0-fold (0.69 log units) away from the limit.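

In this assay, the change from 3,5-dimethylphenyl to 4-fluoro-3,5-dimethylphenyl gives an at least 5.0-fold higher number from compound 1 to compound 3 (0.69 log units; beyond the scatter), so a single fluoro on the aromatic carbon ortho to two methyl groups and para to a large group is enough to move the read-out beyond the scatter. Until now, the only step shown lay at the other end of the shared core, and this result adds that the dimethylphenyl amide end also responds to a change, even one of a single heavy atom. The reading for compound 3 is a limit of the assay, so the size of this step is known only as a lower bound: the limit of > 100000 nM in this assay, at which 2 of the 3 values shown sit.

Going by these compounds, whether the step is particular to fluoro remains open, since chloro, methoxy or an amine on that same carbon would show whether other groups there move the read-out in the same direction or not at all. Also open, on these data alone, is how far beyond the limit compound 3 lies, and whether fluoro on another carbon of this ring, or with either methyl group replaced by hydrogen, would give a step of similar size.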